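Adding a Second Hydroxyl to the Hydrazone Aryl Ring

The source may hold more compounds than are shown below. What is called first, only, known or untested is meant among the compounds shown, and "the series" means these compounds.

Compound 1 `CN(C)CCn1cnnc1-c1cc(Oc2ccc(NC(=O)N/N=C/c3cccc(O)c3)cc2F)ccn1`: 1370 nM
Compound 2 `CN(C)CCn1cnnc1-c1cc(Oc2ccc(NC(=O)N/N=C/c3c(Cl)cccc3Cl)cc2F)ccn1`: 160 nM
Compound 3 `CN(C)CCn1cnnc1-c1cc(Oc2ccc(NC(=O)N/N=C/c3ccc(Cl)cc3Cl)cc2F)ccn1`: 750 nM

In a functional assay on MKN-45 cells (Homo sapiens) for cytotoxicity, read by MTT assay, with a stated time of 72 h (a lower number here means a stronger inhibitor, a higher number a weaker inhibitor), compound 1 gives the highest of the three numbers; compound 3 sits nearest, compound 2 furthest, with an 8.6-fold lower number from compound 1 to compound 2 (0.93 log units; beyond the scatter) and a 1.8-fold lower number from compound 1 to compound 3 (0.26 log units; within the scatter). The step from compound 2 to compound 3 is a 4.7-fold higher number from compound 2 to compound 3 (0.67 log units; beyond the scatter). Compound 4 `CN(C)CCn1cnnc1-c1cc(Oc2ccc(NC(=O)N/N=C/c3ccc(O)cc3O)cc2F)ccn1` differs from compound 1 thus: 2,4-dihydroxyphenyl in place of 3-hydroxyphenyl on a carbon with a double bond to nitrogen. Among the compounds with values here, no measured step swaps one hydroxyphenyl for another, so only the two steps away from compound 1 bear on it, and both point to lower numbers with dichlorophenyls rather than hydroxyphenyls. A small change is therefore expected, a 1.4-fold lower number from compound 1 to compound 4 (0.14 log units; within the scatter). Compound 4 is estimated at 1000 nM, between 300 nM and 3500 nM.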

Compound 4, half-maximal inhibitory concentration: 2860 nM
Beside the measured number, compound 4's estimate is 2.9-fold (0.46 log units) below it; the measured number falls inside the stated range.
By their numbers in this assay, from the lowest: compound 2; then compounds 3 and 1 (each within the scatter of the next); then compound 4.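

In this assay the 2,4-dihydroxyphenyl group moves the number the opposite way from both dichlorophenyls, with a 2.1-fold higher number from compound 1 to compound 4 (0.32 log units; beyond the scatter) beyond the scatter, so adding a second hydroxyl here does not leave the number unchanged. Replacing 2,4-dichlorophenyl with 2,4-dihydroxyphenyl gives a 3.8-fold higher number from compound 3 to compound 4 (0.58 log units; beyond the scatter) at this position, and replacing 2,6-dichlorophenyl gives an 18-fold higher number from compound 2 to compound 4 (1.25 log units; beyond the scatter) as the largest step among these compounds. No measurement shown here accounts for these steps.

Still open, as far as these compounds go, is whether a methoxy group or an amine in place of the hydroxyls would follow the hydroxyphenyls or the dichlorophenyls.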